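A few compounds are considered here, and "the series" means these few. Any claim that something is new, unique, unknown or untested is made for them only; others in the source may bear on it.

Among the compounds with values here, in a functional assay on A549 cells (Homo sapiens) for antiproliferative activity, read by MTT assay, with a stated time of 48 h (a lower number here means a stronger inhibitor, a higher number a weaker inhibitor), compound 2 (`CCCC(=O)O[C@@H]1/C=C/[C@@](C)(CCC=C(C)C)C/C=C(/CO)C(=O)/C=C/[C@@]1(C)O`) gives 4100 nM, the lowest number so far, while compound 1 (`CC(C)=CCC[C@]1(C)/C=C/[C@@H](OC(=O)C(C)C)[C@](C)(O)/C=C/C(=O)/C(CO)=C\C1`) gives 10800 nM. Compound 3 (`CC(C)=CCC[C@]1(C)/C=C/[C@@H](OC(=O)c2ccccc2)[C@](C)(O)/C=C/C(=O)/C(CO)=C\C1`) carries phenyl in place of propyl on a carbonyl carbon. Within the data shown here, the only measured step at this carbonyl carbon, a 2.6-fold lower number from compound 1 to compound 2 (0.42 log units; beyond the scatter), with propyl in place of isopropyl, is modest. No phenyl group has been measured there, so a similarly modest step towards a higher number is expected, with its direction uncertain. The expected change is a 2.1-fold higher number from compound 2 to compound 3 (0.32 log units; beyond the scatter). For compound 3 the estimated value in this assay is 8500 nM, with an expected range of 3000 nM to 24000 nM.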

Compound 3, half-maximal inhibitory concentration: 15800 nM
Compound 3: the middle estimate sits 1.9-fold (0.27 log units) below what was measured, and the stated range covers the measured number.
By their numbers in this assay, from the lowest: compound 2; then compounds 1 and 3 (each within the scatter of the next).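

In this assay, an aromatic ring on this carbonyl carbon is now covered, and phenyl in place of propyl gives a 3.9-fold higher number from compound 2 to compound 3 (0.59 log units; beyond the scatter) and stays on the weaker side of compound 2. Phenyl in place of isopropyl gives a 1.5-fold higher number from compound 1 to compound 3 (0.17 log units; within the scatter) and so separates neither from the other, which leaves the straight propyl ester of compound 2 alone among the three. Nothing shown gives a reason for these differences.

As far as these compounds go, whether a longer chain such as butyl or pentyl on this carbonyl carbon goes beyond compound 2 remains open. So does whether a methoxy group or a chlorine on the phenyl ring shifts compound 3.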